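Working notes on compounds 1 to 4

The compounds below may be only part of what the source reports. "The series", "measured", "known", "first", "only" and "open" are said of these compounds alone.

Values in a functional assay on MCF7 cells (Homo sapiens) for cytotoxicity, read by MTT assay, with a stated time of 24 h; a lower number here means a stronger inhibitor, a higher number a weaker inhibitor:
compound 1, `Cc1ccc(-c2nnc(N3CCN(C(=O)CN4CCN(c5ccc(Cl)cc5)CC4)CC3)nc2-c2ccc(C)cc2)cc1`: 660000 nM
compound 2, `COc1ccc(-c2nnc(N3CCN(C(=O)CN4CCN(c5cccc(Cl)c5)CC4)CC3)nc2-c2ccc(OC)cc2)cc1`: a limit of the assay, > 814000 nM
compound 3, `COc1cccc(N2CCN(CC(=O)N3CCN(c4nnc(-c5ccc(Cl)cc5)c(-c5ccc(Cl)cc5)n4)CC3)CC2)c1`: 149000 nM

Two numbers and one limit are known. Compound 3 gives the lowest of the two numbers; the number of compound 1 stands higher, and that gap lies beyond the usual scatter. Compound 2 sits at the limit (the limit of > 814000 nM in this assay, at which 1 of the 3 values shown sits), so it supplies no number to compare. Going by the values given here, no pair among the measured compounds differs in a single place, so no measured step is available, and the three compounds differ from one another in more than one position at once.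

Compound 4, `O=C(CN1CCN(c2ccc([N+](=O)[O-])cc2)CC1)N1CCN(c2nnc(-c3ccc(Cl)cc3)c(-c3ccc(Cl)cc3)n2)CC1`, is the next compound to be run in this assay. It departs from compound 3 in one place: 4-nitrophenyl in place of 3-methoxyphenyl on an amine nitrogen in a ring, placed on an amine nitrogen in a ring of a six-membered non-aromatic ring with two nitrogens. Among the compounds with values here, nothing among the measured compounds isolates the effect of this group on that nitrogen, so the direction of the step is open. The expectation is a small step, within or near the scatter, in either direction: the step from compound 3 to compound 4 is estimated as a 1.3-fold higher number from compound 3 to compound 4 (0.13 log units; within the scatter). Compound 4 is accordingly expected to give about 200000 nM, within a range of 60000 nM to 700000 nM.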

Compound 4, half-maximal inhibitory concentration: > 789000 nM
Compound 4: a limit, no number; the forecaster's own chance of this, stated with the estimate: 20%; middle value at least 3.9-fold (0.59 log units) away from the limit.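

This position now has its first measured step: 4-nitrophenyl in place of 3-methoxyphenyl on an amine nitrogen in a ring gives an at least 5.2-fold higher number from compound 3 to compound 4 (0.72 log units; beyond the scatter) in this assay. The reading for compound 4 is a limit of the assay and not a number: the limit of > 789000 nM in this assay, at which 1 of the 4 values shown sits. The step therefore gives only a minimum size, but it shows that the group on this nitrogen is not interchangeable in this series, with compound 3 the member of the pair that gives a number, 149000 nM.

As far as these compounds go, the true distance between the two compounds stays open, and this single step cannot separate the loss of 3-methoxyphenyl from the entry of 4-nitrophenyl. Also open, from the compounds shown here alone, are how a phenyl ring carrying a carboxylic acid would read on this same nitrogen, and whether the change would give a step of similar size on the core of compound 1, which carries different groups on its two outer aromatic rings.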